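A few compounds are considered here, and "the series" means these few. Any claim that something is new, unique, unknown or untested is made for them only; others in the source may bear on it.

Compound 1 `O/N=C(/Nc1cccc(Cl)c1)c1ccc2occc2c1`: 1500 nM in an assay on tissue (HeLa cells) for inhibition of Indoleamine 2,3-dioxygenase 1 (Homo sapiens), read by spectrophotometry; a lower number here means a stronger inhibitor, a higher number a weaker inhibitor.
Compound 2 `O/N=C(/Nc1cccc(C(F)(F)F)c1)c1ccc2occc2c1`: 1900 nM in this assay.
Compound 3 `O/N=C(/Nc1cccc(Oc2ccccc2)c1)c1ccc2occc2c1`: in this assay compound 3 is reported only as a limit, > 30000 nM.

Compound 3 thus stands at the edge of what this assay reports; of the three values it is the one sitting at the limit of > 30000 nM in this assay, at which 1 of the 3 values shown sits. The two halogenated analogues are far stronger: an at least 20-fold higher number from compound 1 to compound 3 (1.30 log units; beyond the scatter) and an at least 15-fold higher number from compound 2 to compound 3 (1.19 log units; beyond the scatter), both large, whereas a 1.3-fold higher number from compound 1 to compound 2 (0.10 log units; within the scatter) is within the scatter. Compound 4 `O/N=C(/Nc1cccc(-c2ccccc2)c1)c1ccc2occc2c1` carries phenyl in place of phenoxy on an aromatic carbon. Among the measured compounds shown here, no measured step covers phenyl; the nearest point of reference is compound 3 at the limit of > 30000 nM in this assay, at which 1 of the 3 values shown sits, so compound 4 is expected to stay in that weak region, with a modest downward move, an at least 1.5-fold lower number from compound 3 to compound 4 (0.17 log units; that floor lies within the scatter). Compound 4 is estimated at 20000 nM in this assay, range 6000 nM to 40000 nM.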

Compound 4, half-maximal inhibitory concentration: 11900 nM
Compound 4: the middle estimate sits 1.7-fold (0.23 log units) above what was measured, and the stated range covers the measured number.
By their numbers in this assay, from the lowest: compounds 1 and 2 (each within the scatter of the next); then compound 4. At a limit, above all of these: compound 3.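

Phenyl in place of phenoxy gives a measurable value in this assay, with an at least 2.5-fold lower number from compound 3 to compound 4 (0.40 log units; beyond the scatter). Compound 3 is known only as a limit: the limit of > 30000 nM in this assay, at which 1 of the 4 values shown sits. Phenyl still falls short of both earlier substituents at this position, with a 6.3-fold higher number from compound 2 to compound 4 (0.80 log units; beyond the scatter) and a 7.9-fold higher number from compound 1 to compound 4 (0.90 log units; beyond the scatter), so a six-membered aromatic ring of carbon only is tolerated here only in part, whether or not an oxygen links it.

Open, going by these compounds, is where an amine, a carboxylic acid or a methoxy group in this place would fall relative to compound 1 and compound 4.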